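From compound 3 to compound 4: swapping ring halogens

The compounds below may be only part of what the source reports. "The series", "measured", "known", "first", "only" and "open" are said of these compounds alone.

The measured compounds in an assay for displacement of a labelled ligand from melanin-concentrating hormone receptor 1 (Homo sapiens), read by fluorescence; on this read-out higher numbers stand for weaker inhibition and lower numbers for stronger inhibition:
compound 1 `CC(=O)Nc1cccc(C2CCN(CCCn3c(-c4ccccc4Cl)nc4ccccc43)CC2)c1`: 10 nM
compound 2 `CC(=O)Nc1cccc(C2CCN(CCCn3c(-c4ccc(Cl)cc4Cl)nc4ccccc43)CC2)c1`: 3 nM
compound 3 `CC(=O)Nc1cccc(C2CCN(CCCn3c(-c4ccc(F)c(F)c4)nc4ccccc43)CC2)c1`: 4 nM

Compound 3 gives the second highest of the three numbers in this assay. Its nearest neighbour is compound 2, where a 1.3-fold higher number from compound 2 to compound 3 (0.12 log units; within the scatter) lies within the scatter, so the two cannot be ordered. Its furthest neighbour is compound 1, and a 2.5-fold lower number from compound 1 to compound 3 (0.40 log units; beyond the scatter) is a real but modest improvement.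

Compound 4 `CC(=O)Nc1cccc(C2CCN(CCCn3c(-c4ccc(F)cc4Cl)nc4ccccc43)CC2)c1` carries the change (2-chloro-4-fluorophenyl in place of 3,4-difluorophenyl on an aromatic carbon). The measured steps that bear on it are all about halogens on this pendant ring. Going from the single chloro of compound 1 to the two chloro substituents of compound 2 gave a 3.3-fold lower number from compound 1 to compound 2 (0.52 log units; beyond the scatter), and the two fluoro substituents of compound 3 gave a 2.5-fold lower number from compound 1 to compound 3 (0.40 log units; beyond the scatter) over compound 1. Compound 4 keeps a chloro and a second halogen on the ring, a pattern closer to compound 2 than to compound 1, so no step beyond the scatter is expected from compound 3 in this assay.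

Compound 4 is therefore expected to give about 4 nM in this assay, within a range of 1.5 nM to 10 nM, which amounts to an expected step of no change at the digits printed from compound 3 to compound 4 (within the scatter).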

Compound 4, half-maximal inhibitory concentration: 4 nM
The estimate for compound 4 equals the measured number at the digits printed; measured number inside the range.
By their numbers in this assay, from the lowest: compounds 2, 3 and 4 (each within the scatter of the next); then compound 1.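

In this assay, 2-chloro-4-fluorophenyl in place of 3,4-difluorophenyl, on the aromatic carbon between two ring nitrogen atoms, gave (no change at the digits printed from compound 3 to compound 4 (within the scatter)), so these two halogen patterns cannot be told apart at this position. Fluoro in place of the ring chloro of compound 2 likewise stayed level (a 1.3-fold higher number from compound 2 to compound 4 (0.12 log units; within the scatter)), whereas fluoro in place of hydrogen on the ring of compound 1 gave a small but real gain (a 2.5-fold lower number from compound 1 to compound 4 (0.40 log units; beyond the scatter)); among these four compounds, then, the three with two halogens on this ring sit together, and compound 1, with one, stands apart with the highest number, with no compound going against this. The data offer no measurement that accounts for this tolerance of different halogen patterns.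

From the compounds shown here alone, all four compounds carry only halogens on this phenyl ring, so it remains open whether a methoxy group, a nitrile or an amine in place of a halogen would hold the number at this level. It is also open whether three halogens on the ring, or a trifluoromethyl group, would lower the number further or leave it within the scatter of these compounds.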